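Benzothiazolyl Amide Replaces Chlorophenyl in a Hydroxamate-Free Series

This account rests on a few compounds, and the source may have more. Where it says the series, first, only, none or still open, it means among the compounds named here.

Three compounds sharing one trifluoromethyl gem-diol amide chain were examined in an assay on isolated protein for inhibition of histone deacetylase 4 (Homo sapiens), read by chemiluminescence, with a stated time of 3 h; on this read-out higher numbers stand for weaker inhibition and lower numbers for stronger inhibition. Compound 1 `COc1ccc(NC(=O)CCCCCCNC(=O)C(O)(O)C(F)(F)F)cc1` gives 1600000 nM, compound 2 `COc1ccc2sc(NC(=O)CCCCCCNC(=O)C(O)(O)C(F)(F)F)nc2c1` gives 1900000 nM, and compound 3 `O=C(CCCCCCNC(=O)C(O)(O)C(F)(F)F)Nc1ccc(Cl)cc1` gives 2700000 nM. All three numbers sit within the usual scatter of one another, so compound 3 is not distinguished from compound 2 or compound 1 on this read-out. Among the measured compounds shown here, the single one-place step that has been measured, a 1.7-fold higher number from compound 1 to compound 3 (0.23 log units; within the scatter), is itself within the scatter.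

Compound 4 `O=C(CCCCCCNC(=O)C(O)(O)C(F)(F)F)Nc1nc2ccccc2s1` is not yet measured. Its difference from compound 3 is 1,3-benzothiazol-2-yl in place of 4-chlorophenyl on an amide-type nitrogen. For the measured compounds named here, no measured step covers exactly this change. The closest guide is the pair of compound 1 and compound 2, which differ in the aromatic part bound to the amide nitrogen yet give numbers within the scatter of each other; the step from compound 1 to compound 3 likewise changed nothing beyond the scatter. On that basis the expected step of a 1.1-fold lower number from compound 3 to compound 4 (0.03 log units; within the scatter) is none beyond the scatter. Compound 4 is therefore estimated at 2500000 nM in this assay, with a range from 900000 nM to 7000000 nM.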

Compound 4, half-maximal inhibitory concentration: 430000 nM
The estimate for compound 4 lay 5.8-fold (0.76 log units) above the measured number; measured number below the stated range.
By their numbers in this assay, from the lowest: compound 4; then compounds 1, 2 and 3 (each within the scatter of the next).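

Among the compounds shown here, on the amide-type nitrogen, 1,3-benzothiazol-2-yl in place of 4-chlorophenyl brings a 6.3-fold lower number from compound 3 to compound 4 (0.80 log units; beyond the scatter) in this assay, so the aromatic part at this place is not as indifferent as the earlier compounds, all within the scatter of one another, had suggested. The same holds against the methoxy-bearing phenyl, with a 3.7-fold lower number from compound 1 to compound 4 (0.57 log units; beyond the scatter) for 1,3-benzothiazol-2-yl in place of 4-methoxyphenyl, and compound 4 is the strongest inhibitor of the four on this read-out. Compound 2 goes against any credit to the 1,3-benzothiazol-2-yl group alone, since the loss of its methoxy group gives a 4.4-fold lower number from compound 2 to compound 4 (0.65 log units; beyond the scatter) while compound 2 itself stays within the scatter of compound 1 and compound 3, and nothing given here explains why this one substituent matters so much.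

The compounds shown leave open whether a chloro, an amine or a carboxylic acid on that aromatic carbon would behave like hydrogen or like methoxy. They also leave open whether the lower number of compound 4 would hold with a longer chain, or in this assay with another group in place of the trifluoromethyl gem-diol amide.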